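Hydroxy for trifluoromethyl on the terminal ring

The source may hold more compounds than are shown below. What is called first, only, known or untested is meant among the compounds shown, and "the series" means these compounds.

Measured in a functional assay on KB cells (Homo sapiens) for inhibition, read by sulforhodamine B assay (a higher number here means a weaker inhibitor of growth, a lower number a stronger inhibitor of growth), so far:
compound 1 `Cc1ccc2[nH]c(-c3ccc(-c4ccc(-c5ccc(N(C)C)cc5)cc4)cc3)nc2c1` gives 6240 nM
compound 2 `Oc1ccc(-c2ccc(-c3ccc(-c4nc5ccccc5[nH]4)cc3)cc2)cc1` gives 41000 nM
compound 3 `Cc1ccc2[nH]c(-c3ccc(-c4ccc(-c5ccc(C(F)(F)F)cc5)cc4)cc3)nc2c1` gives 41200 nM

Compound 3 and compound 2 lie within the scatter of each other at the high end of these numbers, while compound 1 lies clearly lower. The next structure is compound 4 `Cc1ccc2[nH]c(-c3ccc(-c4ccc(-c5ccc(O)cc5)cc4)cc3)nc2c1`, with hydroxy in place of trifluoromethyl on an aromatic carbon, para to a large group (hydroxy in place of trifluoromethyl on an aromatic carbon).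

One measured step changes the group at this place on the same core: a 6.6-fold higher number from compound 1 to compound 3 (0.82 log units; beyond the scatter), so the number in this assay does respond to this group, though that rests on a single pair. It does not involve hydroxy. Compound 2 also ends in a 4-hydroxyphenyl group, on a core not identical to that of compound 3. In the same range as compound 3, compound 2 gives 41000 nM. No large gain is therefore expected from hydroxy, and the expectation is a small step toward a lower number, smaller than the measured one, with no change beyond the scatter still possible.

The estimated step is a 2.1-fold lower number from compound 3 to compound 4 (0.31 log units; beyond the scatter) in this reading. For compound 4 the expected value is 20000 nM with an estimated range from 6000 nM to 50000 nM for now.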

Compound 4, concentration for 50% growth inhibition: 21200 nM
The estimate for compound 4 lay 1.1-fold (0.03 log units) below the measured number, and the stated range covers the measured number.
By their numbers in this assay, from the lowest: compound 1; then compounds 4, 2 and 3 (each within the scatter of the next).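

In this assay, hydroxy in place of trifluoromethyl at this place on the shared core gives a 1.9-fold lower number from compound 3 to compound 4 (0.29 log units; within the scatter) and so does not separate these two groups, while hydroxy in place of dimethylamino gives a 3.4-fold higher number from compound 1 to compound 4 (0.53 log units; beyond the scatter) and shows that compound 1 stands apart from compound 4 as well as from compound 3. On this evidence, the response at this position rests on dimethylamino alone, with hydroxy and trifluoromethyl not told apart. Among the compounds shown here, the added methyl on an aromatic carbon, the one difference between compound 2 and compound 4, gives a 1.9-fold lower number from compound 2 to compound 4 (0.29 log units; within the scatter) and so has no effect that this read-out can resolve for compounds ending in 4-hydroxyphenyl, and no measurement at hand bears on the cause of any of these steps.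

The compounds shown leave open whether the lower number of compound 1 belongs to dimethylamino in particular or to amines at this place more widely, which an unsubstituted amine, a diethylamino group or a morpholine could test. A methoxy group or a carboxylic acid in the same place would show whether any oxygen-bearing group departs from hydroxy.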